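From compound 3 to compound 4 at the limit

This account rests on a few compounds, and the source may have more. Where it says the series, first, only, none or still open, it means among the compounds named here.

Values in a functional assay on MCF7 cells (Homo sapiens) for antiproliferative activity, read by MTT assay, with a stated time of 48 h (a lower number here means a stronger inhibitor, a higher number a weaker inhibitor), so far, each of them a limit and not a number:
- compound 1 `COc1cc(-c2cccc3nc(-c4ccc(Br)cc4)oc23)cc(OC)c1OC` gives > 25000 nM as a limit
- compound 2 `COc1cc(-c2cccc3nc(-c4cccc(C)c4)oc23)cc(OC)c1OC` gives > 25000 nM as a limit
- compound 3 `COc1cc(-c2cccc3nc(-c4ccc(N)cc4)oc23)cc(OC)c1OC` gives > 25000 nM as a limit

Compound 3 has only a limit to show, and compounds 1 and 2 are no different, so the whole record is the limit of > 25000 nM in this assay, at which 3 of the 3 values shown sit, and nothing finer. Compound 4 `COc1cc(-c2cccc3nc(-c4ccco4)oc23)cc(OC)c1OC` carries furan-2-yl in place of 4-aminophenyl on an aromatic carbon of the shared core (furan-2-yl in place of 4-aminophenyl on an aromatic carbon). The measured changes at this same place are a step that the two limits leave unreadable from compound 1 to compound 2 and a step that the two limits leave unreadable from compound 2 to compound 3 and also a step that the two limits leave unreadable from compound 1 to compound 3 and none of them gives a size to carry over. None of them brings in a five-membered aromatic ring either. No step beyond the scatter can therefore be forecast in this assay and no direction is expected. The estimated step is a number no higher from compound 3 to compound 4 (the limit leaves the size open) and it rests on the three limits alone. Expected for compound 4 is 25000 nM with an estimated range from 8000 nM to 50000 nM and a good chance of only a limit once more.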

Compound 4, half-maximal inhibitory concentration: > 25000 nM
Compound 4 ended at the assay's limit (the forecaster's own chance of this, stated with the estimate: 75%); the middle value lies on the limit itself.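

No step can be read between compound 4 and compounds 1, 2 or 3 in this assay, since every comparison sets one limit against another: the limit of > 25000 nM in this assay, at which 4 of the 4 values shown sit.

The compounds shown leave open whether any group at this place on the shared core gives a measurable value in this assay, and how large any step would be.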